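A few compounds are considered here, and "the series" means these few. Any claim that something is new, unique, unknown or untested is made for them only; others in the source may bear on it.

Of the compounds shown here, three have been measured in an assay on isolated protein for inhibition of protein kinase C delta type (Homo sapiens), read by TR-FRET, with a stated time of 2 h; on this read-out lower numbers stand for stronger inhibition and higher numbers for weaker inhibition. Compound 1 `CNC(=O)[C@H]1CC[C@@H](Nc2cc(NCc3cnccc3C(F)(F)F)ncc2C#N)CC1` gives 1600 nM. Compound 2 `CC1(C)C[C@H](Nc2cc(NCc3cnccc3C(F)(F)F)ncc2C#N)CC(C)(C)[C@@H]1O` gives 700 nM. Compound 3 `CC1(C)C[C@H](Nc2nc(NCc3cnccc3C(F)(F)F)ncc2C#N)CC[C@@H]1O` gives 800 nM, which puts it second highest of the three numbers; its gap to compound 2 is within the scatter, and its gap to compound 1 is also within the scatter, so the three values cannot be told apart with confidence.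

The next compound, compound 4 `CC1(C)[C@H](O)C[C@H]1Nc1nc(NCc2cnccc2C(F)(F)F)ncc1C#N`, has not yet been measured. It differs from compound 3 in one place: 3-hydroxy-2,2-dimethylcyclobutyl in place of 4-hydroxy-3,3-dimethylcyclohexyl on a nitrogen on an aromatic ring. The rest of the shared core is unchanged, including the nitrile and the trifluoromethyl-bearing pyridine.

Among the compounds with values here, no pair of measured compounds shows what a swap of one hydroxy-dimethyl ring for a smaller one does here, so there is no measured step to lean on. Within the data shown here, the three values so far sit close together despite different ring-bearing groups on that nitrogen, which gives no reason to expect a large move in either direction. The step from compound 3 to compound 4 is therefore expected to be small, a 1.3-fold higher number from compound 3 to compound 4 (0.10 log units; within the scatter), with a slight lean toward a higher number. In this assay compound 4 is estimated at 1000 nM, between 400 nM and 2500 nM.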

Compound 4, half-maximal inhibitory concentration: 4500 nM
Compound 4: middle estimate off by 4.5-fold (0.65 log units), on the low side; measured number above the stated range.
By their numbers in this assay, from the lowest: compounds 2, 3 and 1 (each within the scatter of the next, the first and the last beyond it); then compound 4.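

In this assay, within the data shown here, the group on this nitrogen clearly matters: putting 3-hydroxy-2,2-dimethylcyclobutyl in place of 4-hydroxy-3,3-dimethylcyclohexyl gives a 5.6-fold higher number from compound 3 to compound 4 (0.75 log units; beyond the scatter) and is the only step here between compounds that differ in one place. Both groups carry a hydroxy and two methyl groups on a carbon ring, so having these features is not enough to keep the number low; the groups differ in ring size, four-membered against six-membered, and in where those features sit on the ring. Nothing available here explains why the number rises with this change.

This single step cannot separate the effect of the smaller ring from the effect of the rearranged hydroxy and methyl groups. As far as these compounds go, it also remains open whether a hydroxy-bearing cyclopentyl ring on this nitrogen would give a number closer to that of compound 3 or compound 4, and whether an amine in place of the hydroxy would be tolerated on either ring.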